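The source may hold more compounds than are shown below. What is called first, only, known or untested is meant among the compounds shown, and "the series" means these compounds.

Of the compounds shown here, two sharing one core have been read so far in a functional assay on HCT-116 cells (Homo sapiens) for inhibition, read by MTT assay, with a stated time of 72 h; on this read-out lower numbers stand for stronger inhibition and higher numbers for weaker inhibition. There compound 1 (`COc1cc2c(Oc3ccc(NC(=O)c4nn(-c5ccccc5)cc(C)c4=O)cc3)ccnc2cc1OCCCCCCC(=O)NO`) gives 150 nM and compound 2 (`COc1cc2c(Oc3ccc(NC(=O)c4nn(-c5cccc(C(F)(F)F)c5)cc(C)c4=O)cc3)ccnc2cc1OCCCCCCC(=O)NO`) gives 590 nM, the higher of the two numbers. Compound 3 (`COc1cc2c(Oc3ccc(NC(=O)c4nn(-c5cccc(C)c5)cc(C)c4=O)cc3)ccnc2cc1OCCCCCCC(=O)NO`) has not yet been measured. It departs from compound 2 by methyl in place of trifluoromethyl on an aromatic carbon, meta to a large group (methyl in place of trifluoromethyl on an aromatic carbon). For the measured compounds named here, only one measured step bears on this change: a 3.9-fold higher number from compound 1 to compound 2 (0.59 log units; beyond the scatter), a modest step beyond the scatter, with trifluoromethyl in place of hydrogen on an aromatic carbon. Going by the values given here, compound 1 carries hydrogen on the carbon where compound 3 carries methyl, and no methyl compound has been measured, so this single step is all the evidence there is. A partial return towards the number of compound 1 is therefore expected, with a lower number than that of compound 2. The expected size is a 2.2-fold lower number from compound 2 to compound 3 (0.34 log units; beyond the scatter), a modest step at most. For compound 3 the estimated value is 270 nM, with an expected range from 120 nM to 600 nM.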

Compound 3, half-maximal inhibitory concentration: 370 nM
Beside the measured number, compound 3's estimate is 1.4-fold (0.14 log units) below it, and the stated range covers the measured number.
By their numbers in this assay, from the lowest: compound 1; then compounds 3 and 2 (each within the scatter of the next).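

In this assay, the step with methyl in place of trifluoromethyl is a 1.6-fold lower number from compound 2 to compound 3 (0.20 log units; within the scatter), so at this place on the aromatic ring the two groups cannot be told apart, despite the difference of three fluorine atoms between them. The earlier compounds showed only that trifluoromethyl separates from hydrogen here; the step with methyl in place of hydrogen, a 2.5-fold higher number from compound 1 to compound 3 (0.39 log units; beyond the scatter), shows that the smaller group also gives a number separated from that of the unsubstituted phenyl, so among these three compounds both substituents stand apart from hydrogen and none goes against this. The data offer no explanation for this pattern.

What the compounds shown leave open is whether any other group at this place, such as a methoxy group, a chlorine atom or an amine, would also give a number separated from that of compound 1 or would stay level with it. They also leave open whether the same separation from hydrogen would hold for these groups on a different carbon of that ring.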